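Methyl-to-trifluoromethyl swap on the fused core

This account rests on a few compounds, and the source may have more. Where it says the series, first, only, none or still open, it means among the compounds named here.

compound 1 `CC#C[C@@H](Cc1nnn[nH]1)c1ccc(OCc2ccc3scc(-c4cc(OCCOC)ccc4C)c3c2)cc1` — 26 nM
compound 2 `CC#C[C@@H](Cc1nnn[nH]1)c1ccc(OCc2ccc3sc(C)c(-c4ccc(OCCOC)cc4C)c3c2)cc1` — 32 nM

In a functional assay on cells for agonist activity at Free fatty acid receptor 1 (Rattus norvegicus), read by FLIPR and calcium flux (on this read-out higher numbers stand for an effect only at larger amounts of compound and lower numbers for an effect already at smaller amounts), compound 1 gives 26 nM and compound 2 gives 32 nM. Among the measured compounds shown here, compound 2 carries the higher of the two numbers, but its gap to compound 1 lies within the scatter, so the two read as equivalent; no single-point step between measured compounds exists in this set. Compound 3 `CC#C[C@@H](Cc1nnn[nH]1)c1ccc(OCc2ccc3sc(C(F)(F)F)c(-c4ccc(OCCOC)cc4C)c3c2)cc1` is not yet measured. It differs from compound 2 by trifluoromethyl in place of methyl on an aromatic carbon. The series holds no earlier change at this place, so neither direction nor size can be read from measured pairs. The expected step is a 1.3-fold higher number from compound 2 to compound 3 (0.10 log units; within the scatter), not beyond the scatter. Compound 3 is estimated at 40 nM in this assay, with a range from 15 nM to 110 nM.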

Compound 3, half-maximal effective concentration: 14 nM
Estimate against measurement, compound 3: 2.9-fold (0.46 log units) above; the whole stated range lies above it.
By their numbers in this assay, from the lowest: compounds 3, 1 and 2 (each within the scatter of the next, the first and the last beyond it).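

In this assay, among the compounds shown here, trifluoromethyl in place of methyl on this aromatic carbon next to the ring sulfur gives a 2.3-fold lower number from compound 2 to compound 3 (0.36 log units; beyond the scatter) and provides the only step read at this position so far. The position thus accepts four heavy atoms in place of one, and the number does not merely hold but falls beyond the scatter. Nothing at hand bears on why the step occurs.

The compounds shown leave open whether the lower number is particular to trifluoromethyl or extends to other groups on this carbon, such as chlorine, a nitrile or an ethyl group. They also leave open whether the same swap gives a step of similar size when the neighbouring 4-(2-methoxyethoxy)-2-methylphenyl group is replaced by another aryl group.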